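A few compounds are considered here, and "the series" means these few. Any claim that something is new, unique, unknown or untested is made for them only; others in the source may bear on it.

Measured in a functional assay on K562 cells (Homo sapiens) for cytotoxicity, read by MTT assay, with a stated time of 48 h; on this read-out lower numbers stand for stronger inhibition and higher numbers for weaker inhibition:
- compound 1 `Cc1ccc(CN2CCN(C(=O)CN[C@H]3CCN(S(=O)(=O)Cc4ccccc4)C3)CC2)cc1`: 8200 nM
- compound 2 `O=C(CN[C@H]1CCN(S(=O)(=O)Cc2ccccc2)C1)N1CCN(Cc2ccccc2F)CC1`: 12600 nM

Only these two compounds have been measured, and compound 2 lies within the scatter of compound 1. Compound 3 `Cc1cc(C)c(CN2CCN(C(=O)CN[C@H]3CCN(S(=O)(=O)Cc4ccccc4)C3)CC2)c(C)c1` carries 2,4,6-trimethylphenyl in place of 2-fluorophenyl on a saturated chain carbon bound to an amine nitrogen in a ring.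

For the measured compounds named here, one measured step bears on this change, an exchange at the same place, which gave a 1.5-fold higher number from compound 1 to compound 2 (0.19 log units; within the scatter). Going by the values given here, no measurement yet shows what 2,4,6-trimethylphenyl itself does. Among the compounds with values here, with only that small step as a guide, no step beyond the scatter is expected in this assay, and the range must stay wide. The estimated step is a 1.3-fold lower number from compound 2 to compound 3 (0.12 log units; within the scatter). For compound 3 the expected value is 9500 nM, within an estimated range of 3500 nM to 22000 nM.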

Compound 3, half-maximal inhibitory concentration: 3300 nM
Compound 3: middle estimate off by 2.9-fold (0.46 log units), on the high side, outside the stated range (below it).
By their numbers in this assay, from the lowest: compound 3; then compounds 1 and 2 (each within the scatter of the next).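

With 2,4,6-trimethylphenyl on a saturated chain carbon bound to an amine nitrogen in a ring, this assay records a 3.8-fold lower number from compound 2 to compound 3 (0.58 log units; beyond the scatter) and a 2.5-fold lower number from compound 1 to compound 3 (0.40 log units; beyond the scatter). For the compounds shown here, these are the first steps at this position that lie beyond the scatter, whereas the exchange of 4-methylphenyl for 2-fluorophenyl gave only a 1.5-fold higher number from compound 1 to compound 2 (0.19 log units; within the scatter), which lies within it, so the number here does respond to the choice of aryl group. Nothing in hand accounts for this change.

The compounds shown leave open whether the step needs all three methyl groups of 2,4,6-trimethylphenyl, or whether 2,6-dimethylphenyl would give the same result. They also do not tell how 2,4,6-trifluorophenyl, 2,4,6-trimethoxyphenyl or a larger ring such as naphthyl would read at this place.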